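The compounds below may be only part of what the source reports. "The series", "measured", "known", "first", "only" and "open" are said of these compounds alone.

Compound 1 `COc1nc(C(C)(C)C)ccc1[C@@H](c1ccccc1)[C@@](O)(CCN(C)C)c1cccc2ccccc12`: 27.6 ug/mL.
Compound 2 `COc1nc(-c2ccncc2)ccc1[C@@H](c1ccccc1)[C@@](O)(CCN(C)C)c1cccc2ccccc12`: > 50 ug/mL.

In a toxicity assay on Vero cells (Chlorocebus sabaeus) for cytotoxicity (a higher number here means that more compound is tolerated, a lower number that less compound is tolerated), compound 1 gives 27.6 ug/mL. For compound 2 the assay reports only a limit, > 50 ug/mL, and no number (the limit of > 50 ug/mL in this assay, at which 1 of the 2 values shown sits). The step of an at least 1.8-fold higher number from compound 1 to compound 2 (0.25 log units; that floor lies within the scatter) therefore has a floor that lies within the scatter. Compound 3 `COc1nc(-c2ccc(C(F)(F)F)cc2)ccc1[C@@H](c1ccccc1)[C@@](O)(CCN(C)C)c1cccc2ccccc12` differs from compound 2 by 4-(trifluoromethyl)phenyl in place of pyridin-4-yl on an aromatic carbon. Going by the values given here, only the step of an at least 1.8-fold higher number from compound 1 to compound 2 (0.25 log units; that floor lies within the scatter) is measured, and it concerns a different group entering the shared core, so it offers little direct guidance; the expected step of an at least 1.6-fold lower number from compound 2 to compound 3 (0.22 log units; that floor lies within the scatter) is modest and downward. For compound 3 the expected value is 30 ug/mL, between 12 ug/mL and 60 ug/mL.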

Compound 3, half-maximal cytotoxic concentration: > 50 ug/mL
Compound 3: a limit, no number; the forecaster's own chance of this, stated with the estimate: 30%; at least 1.6-fold (0.22 log units) between middle value and limit.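

In this assay, a second aryl group at this position, 4-(trifluoromethyl)phenyl, again gives a limit and not a number, as pyridin-4-yl did, so a ring carrying no nitrogen also reaches it. Set against tert-butyl, the replacement gives an at least 1.8-fold higher number from compound 1 to compound 3 (0.25 log units; that floor lies within the scatter). The step between compound 2 and compound 3 cannot be read because both values are limits: the limit of > 50 ug/mL in this assay, at which 2 of the 3 values shown sit.

On these data alone, how far the true values of compound 2 and compound 3 lie beyond the limit stays open. So does whether a carboxylic acid or an amine on the entering aromatic ring would keep the reading at the limit.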